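The compounds below may be only part of what the source reports. "The series", "measured", "known", "first", "only" and "open" are said of these compounds alone.

Compound 1 `FC(F)(F)c1ccc(NCc2cn(-c3ccccc3)nc2-c2ccc(Br)cc2)cc1` — in an ADME assay on MDBK cells (Bos taurus) for cytotoxicity, read by MTT assay, with a stated time of 72 h (a higher number here means that more compound is tolerated, a lower number that less compound is tolerated), compound 1 gives 46000 nM.
Compound 2 `Clc1ccc(NCc2cn(-c3ccccc3)nc2-c2ccc(Br)cc2)cc1` — in this assay compound 2 gives > 100000 nM; > 100000 nM (2 entries), which is a limit of the assay rather than a number.

Among the measured compounds shown here, compound 1 is thus the only compound here with a definite number in this assay; the further entry for compound 2 is a limit and so cannot be ranked against it. Compound 3 `FC(F)(F)c1ccc(NCc2cn(-c3ccccc3)nc2-c2ccccc2)cc1` has not been measured in this assay. It differs from compound 1 in one place: hydrogen in place of bromo on an aromatic carbon. The bromo that leaves sits on an aromatic carbon of a six-membered aromatic ring of carbon only, para to a large group, and a hydrogen atom takes its place.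

For the measured compounds named here, no step between two measured compounds exists to show what such a change does in this assay. Both measured compounds tolerate compound at high levels, so the expectation for compound 3 is a small step at most, within the usual scatter or slightly toward more compound tolerated. The step expected from compound 1 to compound 3 is a 1.5-fold higher number from compound 1 to compound 3 (0.18 log units; within the scatter). Compound 3 is estimated at 70000 nM, with a range from 30000 nM to 150000 nM.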

Compound 3, half-maximal cytotoxic concentration: 34000 nM
Compound 3: middle estimate off by 2.1-fold (0.31 log units), on the high side, within the range that was stated.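

In this assay, swapping 4-bromophenyl for phenyl, with a hydrogen atom taking the place of the bromo on the aromatic carbon, gives a 1.4-fold lower number from compound 1 to compound 3 (0.13 log units; within the scatter). Among the compounds shown here, this is the first step in this set that isolates a single change, and it shows that the bromo can be removed from this position without a change that can be told apart from ordinary repeat-to-repeat variation. For this pair, then, the bromine atom makes no readable difference to how much compound the cells tolerate, although one pair cannot show whether that would hold on a different parent compound, and no measured information on the compounds bears on this result.

Still open is how this assay would read with an amine, a carboxylic acid or a longer alkyl chain on this same aromatic carbon, since only bromo and hydrogen are shown there. Also open, on these data alone, is whether hydrogen in place of bromo would read the same on compound 2, whose entries are a limit of the assay and not a number.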